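A few compounds are considered here, and "the series" means these few. Any claim that something is new, unique, unknown or untested is made for them only; others in the source may bear on it.

Measured so far in a functional assay on the whole organism (strain CF-1) with Mus musculus as the target; on this read-out higher numbers stand for an effect only at larger amounts of compound and lower numbers for an effect already at smaller amounts:
compound 1, `Cc1nnc(CN(C)C)n1-c1ccccc1C(=O)c1ccccc1Cl`, gives > 100 mg/kg, a limit of the assay.
compound 2, `Cc1nnc(CN2CCCC2)n1-c1ccc(Cl)cc1C(=O)c1ccccc1Cl`, gives 18 mg/kg.
compound 3, `Cc1nnc(CN2CCCC2)n1-c1ccc(Cl)cc1C(O)c1ccccc1`, gives > 25 mg/kg; > 200 mg/kg (2 entries), both entries being limits of the assay.

Within the data shown here, compound 2 is the only one of the three with a single number in this assay; the other two give limits only, so no measured step between compounds shares a single change with the one considered here.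

Compound 4, `Cc1nnc(CN(C)C)n1-c1ccc(Cl)cc1C(=O)c1ccccc1Cl`, differs from compound 2 by dimethylamino in place of pyrrolidin-1-yl on a saturated chain carbon bound to an aromatic carbon. Compound 1 also carries the dimethylamino group, but it differs from compound 4 in a second place as well, so its limit cannot be read as the effect of this change alone.

Among the measured compounds shown here, with no measured step of this kind, the step of a 1.7-fold higher number from compound 2 to compound 4 (0.22 log units; within the scatter) is expected to be modest, toward a larger dose, and possibly no more than the scatter.

For compound 4 the estimate in this assay is 30 mg/kg, with a range from 10 mg/kg to 100 mg/kg.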

Compound 4, dose for half-maximal effect: 3.2 mg/kg
Estimate against measurement, compound 4: 9.4-fold (0.97 log units) above; measured number outside the range, below it.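

In this assay, the change at this position is not neutral: dimethylamino in place of pyrrolidin-1-yl on a saturated chain carbon bound to an aromatic carbon gives a 5.6-fold lower number from compound 2 to compound 4 (0.75 log units; beyond the scatter). The dimethylamino group alone does not set the dose, since chloro in place of hydrogen on an aromatic carbon gives an at least 31-fold lower number from compound 1 to compound 4 (1.49 log units; beyond the scatter). That second step gives a bound only, with compound 1 resting on a limit of the assay: the limit of > 100 mg/kg in this assay, at which 1 of the 4 values shown sits.

As far as these compounds go, it remains open whether the first step follows the loss of the ring or the smaller count of heavy atoms; diethylamino and piperidin-1-yl at this place would separate the two readings. Also open, from the compounds shown here alone, is whether the same change holds on the core of compound 3, which gives limits only.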